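Aryl-amino swap on a shared core, cytotoxicity outlook

The source may report more compounds than this note shows. Statements on the series, on what has been measured and on what is new or still open speak of the compounds shown alone.

Compound 1, `CCCCCCNc1nc(SCc2ccc(C(F)(F)F)cc2)nc2ccccc12`, gives 20200 nM in a functional assay on MDA-MB-231 cells (Homo sapiens) for cytotoxicity, read by MTT assay, with a stated time of 72 h; on this read-out higher numbers stand for weaker inhibition and lower numbers for stronger inhibition.
Compound 2, `FC(F)(F)c1ccc(CSc2nc(N3CCCCC3)c3ccccc3n2)cc1`, gives 28400 nM in this assay.
Compound 3, `CCOc1ccccc1Nc1nc(SCc2ccc(C(F)(F)F)cc2)nc2ccccc12`, reaches only the limit of the measurement, > 50000 nM, in this assay.

Compound 3 therefore stands at the weak end of the three, with no number of its own, only a limit. The step of an at least 2.4-fold higher number from compound 1 to compound 3 (0.39 log units; beyond the scatter) is beyond the scatter, while a 1.4-fold higher number from compound 1 to compound 2 (0.15 log units; within the scatter) and an at least 1.7-fold higher number from compound 2 to compound 3 (0.24 log units; that floor lies within the scatter) are not, so a hexyl chain on the ring nitrogen does better here than the 2-ethoxyphenyl group.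

Compound 4, `FC(F)(F)c1ccc(CSc2nc(Nc3cccc(C(F)(F)F)c3)c3ccccc3n2)cc1`, is compound 3 with one change: 3-(trifluoromethyl)phenyl in place of 2-ethoxyphenyl on a nitrogen on an aromatic ring. Going by the values given here, no measured step swaps one aromatic group for another on that nitrogen, so the only bearing comes from the limit of > 50000 nM in this assay, at which 1 of the 3 values shown sits, and from the size of an at least 2.4-fold higher number from compound 1 to compound 3 (0.39 log units; beyond the scatter), which places the aryl-amino arrangement weak. Compound 4 is expected to stay near that weak region, with a step of an at least 1.1-fold lower number from compound 3 to compound 4 (0.04 log units; that floor lies within the scatter) in this assay that is not expected to exceed the scatter. The estimate for compound 4 is 45000 nM, within 15000 nM to 100000 nM.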

Compound 4, half-maximal inhibitory concentration: 11100 nM
Compound 4: middle estimate off by 4.1-fold (0.61 log units), on the high side; measured number outside the range, below it.
By their numbers in this assay, from the lowest: compounds 4, 1 and 2 (each within the scatter of the next, the first and the last beyond it). At a limit, above all of these: compound 3.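

An aromatic group on this nitrogen need not leave the compound weak: this assay shows an at least 4.5-fold lower number from compound 3 to compound 4 (0.65 log units; beyond the scatter) when 3-(trifluoromethyl)phenyl replaces 2-ethoxyphenyl, so the choice of aromatic group matters at this position. That step is only a floor, because compound 3 has a limit and no number of its own: the limit of > 50000 nM in this assay, at which 1 of the 4 values shown sits. The steps of a 2.6-fold lower number from compound 2 to compound 4 (0.41 log units; beyond the scatter) for (3-(trifluoromethyl)phenyl)amino in place of piperidin-1-yl and a 1.8-fold lower number from compound 1 to compound 4 (0.26 log units; within the scatter) for 3-(trifluoromethyl)phenyl in place of hexyl show that this aromatic group does better than the piperidine but cannot be told apart from the hexyl chain.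

The two aromatic groups differ in both substituent and printed position, so the compounds shown cannot separate these two changes. As far as these compounds go, how a plain phenyl or a 3-ethoxyphenyl group would behave on this nitrogen remains open.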